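Removing the carbamoyl: what happens to calcium channel inhibition

The source may hold more compounds than are shown below. What is called first, only, known or untested is meant among the compounds shown, and "the series" means these compounds.

Measured so far:
- compound 1 `O=C(c1ccc(OC(F)(F)F)cc1)N1CCC(N(C2CC2)S(=O)(=O)c2cccc(C(F)(F)F)c2)CC1`: 88%
- compound 2 `CS(=O)(=O)c1ccc(F)cc1C(=O)N1CCC(N(C2CC2)S(=O)(=O)c2cccc(C(F)(F)F)c2)CC1`: 34%
- compound 3 `NC(=O)c1ccc(C(=O)N2CCC(N(C3CC3)S(=O)(=O)c3cccc(C(F)(F)F)c3)CC2)cc1`: 0%

In an assay on cells for inhibition of Voltage-dependent L-type calcium channel subunit alpha-1C (Homo sapiens), read by FLIPR and calcium flux, tested at 3 uM (a higher number here means a stronger effect of the compound at the concentration tested, a lower number a weaker effect), compound 3 stands lowest of the three, with compound 2 its nearest neighbour and compound 1 the furthest away. Compound 4 `CN(C)c1cccc(C(=O)N2CCC(N(C3CC3)S(=O)(=O)c3cccc(C(F)(F)F)c3)CC2)c1` differs from compound 3 in one place: 3-(dimethylamino)phenyl in place of 4-carbamoylphenyl on a carbonyl carbon. For the measured compounds named here, two measured steps bear on this: a number 34 percentage points lower from compound 2 to compound 3 (beyond the scatter) and a number 88 percentage points lower from compound 1 to compound 3 (beyond the scatter). Both steps show that the carbamoylphenyl group goes with the weakest inhibition seen, and that swapping the group on the carbonyl carbon can move the read-out a long way. Since compound 4 likewise loses the carbamoyl, an upward step beyond the scatter is expected, though its size is uncertain. The expected step is a number 45 percentage points higher from compound 3 to compound 4 (beyond the scatter), giving an estimate for compound 4 of 45%, within 15% to 80%.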

Compound 4, a percentage reported as inhibition, at one concentration (the size of the read-out at that concentration, not a potency): 63%
Estimate against measurement, compound 4: 18 percentage points below; measured number inside the range.
By their numbers in this assay, from the lowest: compound 3; then compound 2; then compound 4; then compound 1.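

In this assay a phenyl ring without the carbamoyl can restore much of the inhibition: 3-(dimethylamino)phenyl on the carbonyl carbon gives a number 63 percentage points higher from compound 3 to compound 4 (beyond the scatter) and so lifts the read-out well clear of the bottom of the series. With a number 29 percentage points higher from compound 2 to compound 4 (beyond the scatter) and a number 25 percentage points lower from compound 1 to compound 4 (beyond the scatter) in hand, this position gives graded read-outs rather than a simple on or off.

The data offer no measured explanation for these differences. Going by these compounds, how a phenyl ring carrying a plain amine or a carboxylic acid would read also remains open.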